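Halophenyl variation on the ring nitrogen: notes toward compound 3

This account rests on a few compounds, and the source may have more. Where it says the series, first, only, none or still open, it means among the compounds named here.

Measured so far in a functional assay on the whole organism for inhibition, with Mus musculus as the target, at a dose of 25 mg/kg by the oral route; a higher number here means more inhibition at the dose given (going by the name of the read-out), a lower number less inhibition:
compound 1, `Fc1cccc(N2CCN(CCCOc3ccc4c(c3)CCC4)CC2)c1`: 42%
compound 2, `Clc1ccc(N2CCN(CCCOc3ccc4c(c3)CCC4)CC2)cc1`: 58%

Within the data shown here, compound 2 stands highest of the two numbers in this assay; its nearest neighbour is compound 1, and the one computed step, a number 16 percentage points higher from compound 1 to compound 2 (beyond the scatter), is beyond the scatter but modest. Among the measured compounds shown here, that step is the only measured comparison in the set, and it bears on the next change only loosely: it exchanged one halophenyl for another on the same ring nitrogen, whereas the change to compound 3, `Clc1cc(Cl)cc(N2CCN(CCCOc3ccc4c(c3)CCC4)CC2)c1`, is 3,5-dichlorophenyl in place of 4-chlorophenyl on an amine nitrogen in a ring. For the measured compounds named here, the second chlorine and the new substitution pattern have no measured precedent here, so the direction of the step cannot be read from compound 1 and compound 2 alone. Going by the values given here, the only evidence is that swapping halophenyl groups at this position moved the number by a modest amount, as a number 16 percentage points higher from compound 1 to compound 2 (beyond the scatter) shows, so a step of similar or smaller size, in either direction, is expected in this assay. Compound 3 is therefore estimated at 55%, with a range from 35% to 75%, which is expected to mean a step of a number 3 percentage points lower from compound 2 to compound 3 (within the scatter).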

Compound 3, a percentage reported as inhibition, in the whole organism at one dose (the size of the read-out at that dose, not a potency): 0%
Compound 3: the middle estimate sits 55 percentage points above what was measured; the whole stated range lies above it.
By their numbers in this assay, from the lowest: compound 3; then compound 1; then compound 2.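

In this assay, replacing 4-chlorophenyl with 3,5-dichlorophenyl on an amine nitrogen in a ring gives a number 58 percentage points lower from compound 2 to compound 3 (beyond the scatter), a far larger change than the modest a number 16 percentage points higher from compound 1 to compound 2 (beyond the scatter) seen between the first two halophenyl groups. The comparison with the other single-halogen compound points the same way, with a number 42 percentage points lower from compound 1 to compound 3 (beyond the scatter), so compound 3 lies under both earlier compounds and this position proves much less forgiving of halophenyl exchange than the first pair suggested: the read-out can fall to nothing at this dose, not merely shift by a modest amount. Nothing available explains this fall.

The compounds shown do not separate the effect of the second chlorine from that of the new substitution pattern, and an unsubstituted phenyl, a methoxyphenyl or a pyridyl group on the same nitrogen would show how far the series extends beyond halophenyl groups. On these data alone, with a single dose and a single whole-organism read-out, it also remains open whether the result for compound 3 reflects a complete loss of activity or only its absence at this dose and route.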